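Swapping the aryl ketone ring for a bromothiophene

The compounds below may be only part of what the source reports. "The series", "measured", "known", "first", "only" and "open" are said of these compounds alone.

The measured compounds, each with its result in a functional assay on MCF7 cells (Homo sapiens) for antiproliferative activity, read by XTT assay, with a stated time of 72 h; a lower number here means a stronger inhibitor, a higher number a weaker inhibitor:
- compound 1 `COc1ccc(-c2cc3ccccc3nc2/C=C/C(=O)c2ccccc2)cc1`: 4040 nM
- compound 2 `COc1ccc(-c2cc3ccccc3nc2/C=C/C(=O)c2ccc(O)cc2)cc1`: 6710 nM
- compound 3 `COc1ccc(-c2cc3ccccc3nc2/C=C/C(=O)c2ccc([N+](=O)[O-])cc2)cc1`: 4110 nM

All three share one core and differ only in the group on the far phenyl ring of the ketone. Compound 3 sits second highest of the three, but its distance to compound 1, a 1.0-fold higher number from compound 1 to compound 3 (0.01 log units; within the scatter), and to compound 2, a 1.6-fold lower number from compound 2 to compound 3 (0.21 log units; within the scatter), both fall inside the ordinary scatter, so nothing separates the three in this assay.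

Compound 4 `COc1ccc(-c2cc3ccccc3nc2/C=C/C(=O)c2ccc(Br)s2)cc1` makes a different kind of change: 5-bromothiophen-2-yl in place of 4-nitrophenyl on a carbonyl carbon. The measured steps, a 1.7-fold higher number from compound 1 to compound 2 (0.22 log units; within the scatter) and a 1.0-fold higher number from compound 1 to compound 3 (0.01 log units; within the scatter), only decorate the phenyl ring; none replaces the ring itself, so they bear on compound 4 only loosely. They show that changes at this end of the molecule have so far left the number where it was. The expectation for compound 4 is therefore no step beyond the scatter, a 1.0-fold lower number from compound 3 to compound 4 (0.01 log units; within the scatter), with a wider range than usual to allow for the untested ring swap. Compound 4 is estimated at 4000 nM, between 1300 nM and 12000 nM.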

Compound 4, half-maximal inhibitory concentration: 910 nM
For compound 4 the middle estimate is 4.4-fold (0.64 log units) above the measured one; the measured number lies below the stated range.
By their numbers in this assay, from the lowest: compound 4; then compounds 1, 3 and 2 (each within the scatter of the next).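

The bromothiophene brings a 4.4-fold lower number from compound 1 to compound 4 (0.65 log units; beyond the scatter) and a 4.5-fold lower number from compound 3 to compound 4 (0.65 log units; beyond the scatter) and also a 7.4-fold lower number from compound 2 to compound 4 (0.87 log units; beyond the scatter) in this assay and so shows that this position can respond. Replacing the phenyl ring on the carbonyl carbon outright moved the number beyond the scatter, which hydroxy and nitro on that ring did not do. No measurement here explains what about the 5-bromothiophen-2-yl group produces this step.

As far as these compounds go, with a single such ring, it stays open whether the bromine, the thiophene ring or the two together matter, and a thiophen-2-yl group without bromine would help to separate them. Also open, from the compounds shown here alone, is how a furan ring or a pyridine ring would behave on the same carbonyl carbon.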